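The compounds below may be only part of what the source reports. "The series", "measured", "known", "first", "only" and "open" are said of these compounds alone.

Of the compounds shown here, three have so far been tested in a functional assay on cells (CNS carcinoma cell, Homo sapiens) for cytotoxicity, read by sulforhodamine B assay, with a stated time of 48 h; a lower number here means that less compound is tolerated, a higher number that more compound is tolerated. Compound 1 `COc1cc2c(cc1C)NC(=O)/C2=C/c1c(OC)nc2sc(C)cn12` gives 68300 nM, compound 2 `COc1nc2sc(C)cn2c1C=C1C(=O)N(C)c2ccccc21` gives 97300 nM, and compound 3 `O=C1Nc2ccccc2C1=Cc1c(-c2ccncc2)nc2sccn12` gives 95000 nM. Compound 1 therefore stands level with the other two. Its value lies within the usual scatter of repeated measurements from each of them, so these numbers cannot be ranked.

Compound 4 `COc1ccc2c(c1)/C(=C\c1c(OC)nc3sc(C)cn13)C(=O)N2` keeps the core of compound 1 and carries one small change: hydrogen in place of methyl on an aromatic carbon. In words, hydrogen takes the place of methyl on an aromatic carbon, ortho to a methoxy group.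

Among the measured compounds shown here, no two measured compounds differ in only one place, so no measured step speaks directly for this change. The indirect evidence is limited. Compound 3, at 95000 nM, differs from compound 1 in more than one place, yet its value stays within the scatter of compound 1 at 68300 nM. On that basis, no shift beyond the scatter is expected in this assay, in either direction. The estimated step of a 1.2-fold higher number from compound 1 to compound 4 (0.07 log units; within the scatter) stays within the usual scatter. The expected value for compound 4 is 80000 nM, with an estimated range from 48000 nM to 100000 nM.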

Compound 4, concentration lethal to 50% of the cells: 85400 nM
The estimate for compound 4 lay 1.1-fold (0.03 log units) below the measured number, within the range that was stated.
By their numbers in this assay, from the lowest: compounds 1, 4, 3 and 2 (each within the scatter of the next).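

Among the compounds shown here, replacing methyl with hydrogen on this aromatic carbon, ortho to a methoxy group, gives the first direct reading of a single change in this assay, and that reading is a 1.3-fold higher number from compound 1 to compound 4 (0.10 log units; within the scatter). Until now, the comparison among the compounds rested only on structures that differ in more than one place, whereas this pair isolates one position and shows that the methyl group can be removed from it with no change that stands out from the usual variation between repeats, so compound 1 and compound 4 stand level. The data include no separate measurement that would explain this outcome, so the result records what happens at this position but not the reason for it.

As far as these compounds go, with only methyl and hydrogen compared at this carbon, it remains open whether a quite different group there, such as an amine, a carboxylic acid or a longer chain, would move the number beyond the scatter. From the compounds shown here alone, it also remains open whether the same swap would stay as quiet if the neighbouring methoxy group were replaced by something else.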